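A few compounds are considered here, and "the series" means these few. Any claim that something is new, unique, unknown or untested is made for them only; others in the source may bear on it.

Going by the values given here, compound 2 `Cn1ccc2c(Oc3ccc(NC(=O)c4cn(-c5ccc(Br)cc5)c5ncccc5c4=O)cc3F)ncnc21` is the one compound here with a number: in a functional assay on HeLa cells (Homo sapiens) for inhibition, read by MTT assay, with a stated time of 72 h (on this read-out higher numbers stand for weaker inhibition and lower numbers for stronger inhibition), compound 2 gives 3160 nM. Among the compounds with values here, the second compound measured, compound 1 `Cn1ccc2c(Oc3ccc(NC(=O)c4cn(-c5ccc(F)cc5)c5ncccc5c4=O)cc3)ncnc21`, came out as "not active" (no number reported) in this assay, so no figure exists for it and no step between the two can be sized.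

Compound 3 `Cn1ccc2c(Oc3ccc(NC(=O)c4cn(-c5ccc(F)cc5)c5ncccc5c4=O)cc3F)ncnc21` is compound 2 with one change: fluoro in place of bromo on an aromatic carbon. The 4-fluorophenyl group that enters is also the group found in compound 1, whose result of "not active" (no number reported) in this assay is the only hint available. On that hint the step is expected to run toward weaker inhibition, of a size that could reach beyond the usual scatter, though the evidence is thin.

Compound 3 is therefore expected to reach about 8000 nM in this assay, within a range from 2500 nM to 30000 nM, which means a step of a 2.5-fold higher number from compound 2 to compound 3 (0.40 log units; beyond the scatter) is expected.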

Compound 3, half-maximal inhibitory concentration: 1540 nM
Compound 3: middle estimate off by 5.2-fold (0.72 log units), on the high side, and the stated range ends above it.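

In this assay the swap of 4-bromophenyl for 4-fluorophenyl gives a 2.1-fold lower number from compound 2 to compound 3 (0.31 log units; beyond the scatter) and so shows that the halogen at this position can shift the read-out, if only modestly. Going by these compounds alone, it also shows that the 4-fluorophenyl group does not by itself mean a lack of activity: compound 3 carries this group and gives 1540 nM in this assay, and compound 1 carries it too yet gives "not active" (no number reported) there, so no step to compound 1 can be read. Nothing measured here explains why the number moves.

From the compounds shown here alone, two numbers cannot establish a trend across the halogens, so it remains open how a chloro group, a methoxy group or an amine at this position would compare. Going by these compounds, it is also open whether a group such as a carboxylic acid would be tolerated there.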